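The source may report more compounds than this note shows. Statements on the series, on what has been measured and on what is new or still open speak of the compounds shown alone.

Compound 1 `COc1ccc(C(=O)/C=C/c2cccc(F)c2)c2c1C=CC(C)(C)O2` in a functional assay on HepG2 cells (Homo sapiens) for antiproliferative activity, read by MTT assay, with a stated time of 24 h (on this read-out lower numbers stand for stronger inhibition and higher numbers for weaker inhibition), gives > 10000 nM, which is a limit of the assay and not a number.
Compound 2 `COc1ccc(C(=O)/C=C/c2ccc(N(C)C)cc2)c2c1C=CC(C)(C)O2` in this assay gives 730 nM.
Compound 3 `COc1ccc(C(=O)/C=C/c2ccc(-c3ccccc3)cc2)c2c1C=CC(C)(C)O2` in this assay gives > 10000 nM, again a limit of the assay rather than a number.

Compound 3 therefore stands at the limit of > 10000 nM in this assay, at which 2 of the 3 values shown sit, together with compound 1, while compound 2 alone returns a number. The two measured steps are both large: an at least 13-fold lower number from compound 1 to compound 2 (1.13 log units; beyond the scatter) and an at least 13-fold higher number from compound 2 to compound 3 (1.13 log units; beyond the scatter).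

The next compound, compound 4 `COc1ccc(C(=O)/C=C/c2ccc(-n3ccnc3)cc2)c2c1C=CC(C)(C)O2`, differs from compound 3 by 1H-imidazol-1-yl in place of phenyl on an aromatic carbon. No measured step swaps one ring for another ring at this position; the steps shown concern a dimethylamino group entering and leaving, so they bear on the change only indirectly. Since compound 3 sits at a limit, the direction can only be toward a lower number or no change beyond the scatter. Compound 4 is expected to give 6000 nM, within 1000 nM to 30000 nM, meaning an estimated at least 1.6-fold lower number from compound 3 to compound 4 (0.22 log units; that floor lies within the scatter).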

Compound 4, half-maximal inhibitory concentration: > 10000 nM
Compound 4: no number, only a limit (the forecaster's own chance of this, stated with the estimate: 45%); middle value at least 1.6-fold (0.22 log units) away from the limit.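

In this assay, 1H-imidazol-1-yl in place of dimethylamino on this aromatic carbon brings an at least 13-fold higher number from compound 2 to compound 4 (1.13 log units; beyond the scatter), so a group containing nitrogen does not by itself preserve the activity seen with compound 2. The exchange of phenyl for 1H-imidazol-1-yl cannot be read, as both compounds give only a limit of the assay. Among the compounds shown, dimethylamino in compound 2 is the only group that gives a number, while compound 1, compound 3 and compound 4 share one limit: the limit of > 10000 nM in this assay, at which 3 of the 4 values shown sit.

From the compounds shown here alone, it remains open whether the number depends on dimethylamino itself or would also be reached with a smaller amine such as methylamino or a saturated ring amine such as morpholine. Going by these compounds, how far compound 1, compound 3 and compound 4 differ from one another also stays unknown.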